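Butoxy to Nitro: Cytotoxicity Still Expected at the Limit

The source may report more compounds than this note shows. Statements on the series, on what has been measured and on what is new or still open speak of the compounds shown alone.

Three compounds share one core and differ only in the group on the pendant aromatic ring. Compound 1 `CCOC(=O)c1c(-c2cccc(-c3ccccc3)c2)[nH]c2cc(OC)ccc2c1=O` carries a phenyl there, compound 2 `CCOC(=O)c1c(-c2cccc(OC(C)C)c2)[nH]c2cc(OC)ccc2c1=O` an isopropoxy, and compound 3 `CCCCOc1cccc(-c2[nH]c3cc(OC)ccc3c(=O)c2C(=O)OCC)c1` a butoxy. In an ADME assay on BJ cells (Homo sapiens) for cytotoxicity, read by luminescence, with a stated time of 72 h (a lower number here means that less compound is needed, a higher number that more compound is needed for the effect), compound 1 gives only a limit, > 21500 nM. Compound 2 likewise gives only a limit in this assay, > 21500 nM. Compound 3 also stands at a limit in this assay, > 21500 nM, so no number is known for it. Because (the limit of > 21500 nM in this assay, at which 3 of the 3 values shown sit), the steps a step that the two limits leave unreadable from compound 1 to compound 2, a step that the two limits leave unreadable from compound 1 to compound 3 and a step that the two limits leave unreadable from compound 2 to compound 3 cannot be read in size or direction. Compound 4 `CCOC(=O)c1c(-c2cccc([N+](=O)[O-])c2)[nH]c2cc(OC)ccc2c1=O` has not yet been measured; it differs from compound 3 by nitro in place of butoxy on an aromatic carbon. Within the data shown here, none of the measured steps gives a readable size, so no step beyond the scatter is expected in this assay, and compound 4 is expected to stay at the limit. For compound 4 in this assay the estimate is 30000 nM, within 15000 nM to 80000 nM. The expected step is a step that the limit leaves unreadable from compound 3 to compound 4, an estimate only.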

Compound 4, half-maximal effective concentration: > 21500 nM
Compound 4 ended at the assay's limit; the forecaster's own chance of this, stated with the estimate: 80%; the middle value does not contradict the limit.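

The steps from compound 1, compound 2 and compound 3 to compound 4 in this assay cannot be read in size or direction, because the values are limits and not numbers: the limit of > 21500 nM in this assay, at which 4 of the 4 values shown sit.

The compounds shown leave open at what concentration any of them would reach the half-maximal effect, and whether the group on the pendant aromatic ring matters.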